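The source may report more compounds than this note shows. Statements on the series, on what has been measured and on what is new or still open speak of the compounds shown alone.

Compound 1, `C[C@]1(O)C[C@](c2cccc(OC(F)(F)F)c2)([C@H](O)c2ccccn2)C1`, gives 1310 nM in an assay on HEK293 cells for antagonist activity at transient receptor potential cation channel subfamily V member 3 (Homo sapiens), read by FLIPR and calcium flux; a lower number here means a stronger inhibitor, a higher number a weaker inhibitor. Compound 2, `O[C@H](c1ccccn1)[C@]1(c2cccc(OC(F)(F)F)c2)C[C@H](O)C1`, gives 40 nM. Compound 3, `C[C@]1(O)C[C@](c2cccc(C(F)(F)F)c2)([C@H](O)c2ccccn2)C1`, gives 1550 nM.

Compound 3 stands highest of the three numbers, but compound 1 lies within the scatter of it (a 1.2-fold higher number from compound 1 to compound 3 (0.07 log units; within the scatter)), so only compound 2 is clearly set apart. Compound 4, `O[C@H](c1ccccn1)[C@]1(c2cccc(C(F)(F)F)c2)C[C@H](O)C1`, differs from compound 3 by hydrogen in place of methyl on a saturated ring carbon. One measured step of the same kind exists: a 33-fold lower number from compound 1 to compound 2 (1.52 log units; beyond the scatter). The change of trifluoromethoxy to trifluoromethyl, seen in the step from compound 1 to compound 3, stayed within the scatter, so the large step is expected to carry over to compound 4 as a 31-fold lower number from compound 3 to compound 4 (1.49 log units; beyond the scatter). Compound 4 is therefore estimated at 50 nM, with a range from 20 nM to 150 nM.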

Compound 4, antagonist equilibrium constant: 90 nM
Estimate against measurement, compound 4: 1.8-fold (0.26 log units) below, and the stated range covers the measured number.
By their numbers in this assay, from the lowest: compound 2; then compound 4; then compounds 1 and 3 (each within the scatter of the next).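

On the saturated ring carbon of the four-membered ring, hydrogen in place of methyl also gives a large step with trifluoromethyl on the aromatic ring (a 17-fold lower number from compound 3 to compound 4 (1.24 log units; beyond the scatter)), so the effect is not confined to the trifluoromethoxy compounds, and its size holds across the two cores: the same change on two cores in this assay, a 33-fold lower number (1.52 log units; beyond the scatter) from compound 1 to compound 2 and a 17-fold lower number (1.24 log units; beyond the scatter) from compound 3 to compound 4, 1.9-fold (0.28 log units) apart, within the scatter of two such steps.
With hydrogen on that carbon, trifluoromethyl in place of trifluoromethoxy now gives a modest step (a 2.3-fold higher number from compound 2 to compound 4 (0.35 log units; beyond the scatter)), yet this does not differ reliably from the same change with methyl there: the same change on two cores in this assay, a 1.2-fold higher number (0.07 log units; within the scatter) from compound 1 to compound 3 and a 2.3-fold higher number (0.35 log units; beyond the scatter) from compound 2 to compound 4, 1.9-fold (0.28 log units) apart, within the scatter of two such steps.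

Among these compounds, only hydrogen and methyl occupy this ring carbon, so it remains open how an ethyl group or a fluorine atom there would compare. Also open, as far as these compounds go, is how a nitrile on the aromatic ring would compare with the two fluorinated groups.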